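One Aryl Swap Measured, a Second Still Open

The source may hold more compounds than are shown below. What is called first, only, known or untested is meant among the compounds shown, and "the series" means these compounds.

compound 1 `CCN1CCc2c(c(C(C)(C)C)nn2C(=O)Nc2ccc(F)cc2F)C1` — 71.9%
compound 2 `CCN1CCc2c(c(C(C)(C)C)nn2C(=O)Nc2cc(C)ccc2F)C1` — 17.5%

Two compounds share one core and differ only in the aryl group on the amide-type nitrogen. In a functional assay on the whole organism (strain Swiss albino) for inhibition, with Mus musculus as the target, in the writhing test, with a stated time of 30 min, at a dose of 100 mg/kg (a lower number here means less inhibition, a higher number more inhibition at the dose given (going by the name of the read-out)), compound 1 gives 71.9%, while compound 2 gives 17.5%, the lower of the two numbers. The step of a number 54.4 percentage points lower from compound 1 to compound 2 (beyond the scatter) is the only one measured, and it shows that a change of the aryl group alone can move this assay a long way.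

Compound 3 `CCN1CCc2c(c(C(C)(C)C)nn2C(=O)Nc2ccc(Cl)cc2)C1` has not been measured. It differs from compound 2 as follows: 4-chlorophenyl in place of 2-fluoro-5-methylphenyl on an amide-type nitrogen. Among the compounds with values here, no measured step joins a 4-chlorophenyl to either aryl group already seen, so the one known step only shows how wide the swing between aryl groups can be; it does not point in a direction. The expectation for compound 3 is therefore placed between the two measured values, with a wide range: 45%, a step of a number 27.5 percentage points higher from compound 2 to compound 3 (beyond the scatter).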

Compound 3, a percentage reported as inhibition, in the whole organism at one dose (the size of the read-out at that dose, not a potency): 15.8%
Compound 3: the middle estimate sits 29.2 percentage points above what was measured; the range from low to high includes it.
By their numbers in this assay, from the lowest: compounds 3 and 2 (each within the scatter of the next); then compound 1.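

In this assay the aryl swap on the amide-type nitrogen gives a number 1.7 percentage points lower from compound 2 to compound 3 (within the scatter) and so leaves 4-chlorophenyl and 2-fluoro-5-methylphenyl indistinguishable at this dose, although the two groups differ in their atoms. Replacing 2,4-difluorophenyl with 4-chlorophenyl gives a number 56.1 percentage points lower from compound 1 to compound 3 (beyond the scatter) and thus shows that the large gap seen earlier is not tied to a single replacement: among these three compounds, only compound 1 stands apart. Nothing available explains why the 2,4-difluorophenyl compound separates from the other two.

On these data alone, it remains open whether a 4-fluorophenyl or a 2-fluorophenyl group on the same nitrogen would keep the reading of compound 1 or fall in with compound 2 and compound 3. As far as these compounds go, how an unsubstituted phenyl or a 2,4-dichlorophenyl group would read there is also open.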